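Adding a chloro group beside trifluoromethyl: compound 4

The source may hold more compounds than are shown below. What is called first, only, known or untested is meant among the compounds shown, and "the series" means these compounds.

Measured compounds:
compound 1 `O=C(Nc1cccc(-n2cc(-c3ccncc3)c(-c3ccc(Cl)c(O)c3)n2)c1)Nc1cccc(C(F)(F)F)c1` gives 1060 nM
compound 2 `COc1cc(-c2nn(-c3cccc(NC(=O)Nc4cccc(C(F)(F)F)c4)c3)cc2-c2ccncc2)ccc1Cl` gives 580 nM
compound 3 `O=C(Nc1cccc(-n2cc(-c3ccncc3)c(-c3ccc(Cl)c(O)c3)n2)c1)Nc1cc(C(F)(F)F)cc(C(F)(F)F)c1` gives 400 nM

These three share one core and were all tested in a functional assay on OVCAR-3 cells (Homo sapiens) for inhibition, read by sulforhodamine B assay, with a stated time of 48 h; a higher number here means a weaker inhibitor, a lower number a stronger inhibitor. Compound 1 stands with the highest number of the three: compound 2 sits a 1.8-fold lower number from compound 1 to compound 2 (0.26 log units; within the scatter), and compound 3 sits a 2.7-fold lower number from compound 1 to compound 3 (0.42 log units; beyond the scatter).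

The unmeasured compound 4 `O=C(Nc1cccc(-n2cc(-c3ccncc3)c(-c3ccc(Cl)c(O)c3)n2)c1)Nc1ccc(Cl)c(C(F)(F)F)c1` differs from compound 1 in one place: chloro in place of hydrogen on an aromatic carbon. The chloro enters on an aromatic carbon of a six-membered aromatic ring of carbon only, ortho to a trifluoromethyl group, so the change lands on the same ring that was altered from compound 1 to compound 3. Neither measured step is an exact match. The step to compound 2 changed a different part of the molecule and stayed within the scatter. The step to compound 3, which added a second trifluoromethyl to that ring, gave a modest lowering. A second substituent on that ring is therefore expected to lower the number by a modest amount or leave it within the scatter, and compound 4 is expected at 600 nM, within 300 nM to 1300 nM, that is a 1.8-fold lower number from compound 1 to compound 4 (0.25 log units; within the scatter).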

Compound 4, half-maximal inhibitory concentration: 830 nM
Estimate against measurement, compound 4: 1.4-fold (0.14 log units) below, within the range that was stated.
By their numbers in this assay, from the lowest: compounds 3, 2, 4 and 1 (each within the scatter of the next, the first and the last beyond it).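

Changing 3-(trifluoromethyl)phenyl to 4-chloro-3-(trifluoromethyl)phenyl gives a 1.3-fold lower number from compound 1 to compound 4 (0.11 log units; within the scatter) in this assay, so this read-out does not separate the two compounds. Until now, the only added substituent on this ring was a second trifluoromethyl, with a 2.7-fold lower number from compound 1 to compound 3 (0.42 log units; beyond the scatter), and the new result shows that adding a second substituent to this ring does not always give a step beyond the scatter. Compound 3 and compound 4 differ in both the added group and its place on the ring, and no evidence available here explains the outcome at this carbon.

The compounds shown leave open whether another group on this same carbon, such as an amine, a nitrile or a carboxylic acid, would give a step beyond the scatter. They also leave open whether a chloro on this carbon would give a similar result when the hydrogen on the oxygen of the other aromatic ring is replaced by methyl, as it is in compound 2.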